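This account rests on a few compounds, and the source may have more. Where it says the series, first, only, none or still open, it means among the compounds named here.

Compound 1 `COc1cc(-c2cc(/C=C/C(=O)c3ccc(N)cc3)[nH]n2)cc(OC)c1OC` gives 88% in a functional assay on MDA-MB-435 cells (Homo sapiens) for cytotoxicity, read by sulforhodamine B assay, with a stated time of 48 h, tested at 1 uM; a higher number here means a weaker effect of the compound at the concentration tested, a lower number a stronger effect. Compound 2 `COc1ccc(C(=O)/C=C/c2cc(-c3cc(OC)c(OC)c(OC)c3)n[nH]2)cc1` gives 92% in this assay. Compound 3 `COc1cc(-c2cc(/C=C/C(=O)c3ccc(F)c(F)c3)[nH]n2)cc(OC)c1OC` is not yet measured.

Compound 2 shows the higher of the two numbers, yet the step of a number 4 percentage points higher from compound 1 to compound 2 (within the scatter) lies within the scatter, so the two compounds cannot be ordered. Compound 3 differs from compound 2 by 3,4-difluorophenyl in place of 4-methoxyphenyl on a carbonyl carbon. Among the measured compounds shown here, the only measured step, from compound 1 to compound 2, also altered the aryl group on the carbonyl carbon and produced no change beyond the scatter, so no step beyond the scatter is expected, a number 4 percentage points lower from compound 2 to compound 3 (within the scatter). Compound 3 is therefore expected to give 88% in this assay, between 70% and 100%.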

Compound 3, a percentage reported as activity, at one concentration (the size of the read-out at that concentration, not a potency): 88%
Beside the measured number, compound 3's estimate shows no gap at the digits printed; measured number inside the range.
By their numbers in this assay, from the lowest: compounds 1, 3 and 2 (each within the scatter of the next).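

In this assay, the exchange on the carbonyl carbon gives a number 4 percentage points lower from compound 2 to compound 3 (within the scatter) and also no change at the digits printed from compound 1 to compound 3 (within the scatter). Compared with the earlier pair, this position now holds a fluorine-bearing ring, 3,4-difluorophenyl, with no hydrogen-bond acceptor, and still no step lies beyond the scatter. No measurement shown offers a reason for these numbers. The compounds leave open whether a carboxylic acid on the phenyl ring, or a cyclohexyl group in its place, would give a step beyond the scatter. They also leave open how these three compounds would compare at other concentrations.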